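Bromo in place of ethoxycarbonyl on the shared core

The source may hold more compounds than are shown below. What is called first, only, known or untested is meant among the compounds shown, and "the series" means these compounds.

Among the compounds with values here, compound 1 `CCCCc1cc2c(=O)c(C(=O)OCC)c[nH]c2cc1OCCOc1ccccc1` and compound 2 `CCCc1cc2c(=O)c(C(=O)OC)c[nH]c2cc1OCCOc1ccccc1` share one core and differ from each other in two places, so no single-change step joins them. In an ADME assay on J774 cells (Mus musculus) for cytotoxicity (on this read-out higher numbers stand for an effect only at larger amounts of compound and lower numbers for an effect already at smaller amounts), compound 1 gives > 20000 nM, which is a limit of the assay rather than a number. In this assay compound 2 gives > 20000 nM, again a limit. Compound 1 therefore stands where every value shown stands, at the edge of what the assay reports: the limit of > 20000 nM in this assay, at which 2 of the 2 values shown sit. Within the data shown here, no step between two measured compounds is available, so nothing measured tells how any change on this core moves the read-out.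

Compound 3 `CCCCc1cc2c(=O)c(Br)c[nH]c2cc1OCCOc1ccccc1` is the next member. It differs from compound 1 in one place (bromo in place of ethoxycarbonyl on an aromatic carbon). Both measured values sit at the same limit. No size or direction of effect can be read from them for this change. Compound 3 is expected to remain at the limit, the estimated step being a step that the limit leaves unreadable from compound 1 to compound 3. For compound 3 the estimated value in this assay is 30000 nM, with a range from 10000 nM to 100000 nM.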

Compound 3, half-maximal effective concentration: 8070 nM
For compound 3 the middle estimate is 3.7-fold (0.57 log units) above the measured one, outside the stated range (below it).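

Within the data shown here, the position on the aromatic carbon, two atoms from the ring nitrogen, is the first place on the shared core where a change gives a readable effect in this assay: bromo in place of ethoxycarbonyl gives an at least 2.4-fold lower number from compound 1 to compound 3 (0.39 log units; beyond the scatter), so cytotoxicity appears at smaller amounts of compound with bromo at this position. The value of compound 1 is a limit, which makes this step a minimum size and leaves its full size unknown. Compound 3 is also the only compound shown with a value inside the reported range, and the others stay at the edge: the limit of > 20000 nM in this assay, at which 2 of the 3 values shown sit.

The swap removes five heavy atoms, including both hydrogen-bond acceptors of the ethoxycarbonyl, and brings in one bromine, so the step alone cannot separate the departure of the ester from the arrival of the halogen. Going by these compounds, a carboxylic acid, a primary amide, a chloro group or plain hydrogen at this position on the core of compound 1 would show which of the two the read-out follows, and whether the butyl chain plays any part remains open.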